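Moving the chain double bond of compound 1

The source may hold more compounds than are shown below. What is called first, only, known or untested is meant among the compounds shown, and "the series" means these compounds.

In a functional assay on HeLa cells (Homo sapiens) for antiproliferative activity, read by XTT assay, with a stated time of 72 h (a lower number here means a stronger inhibitor, a higher number a weaker inhibitor), compound 1 (`C=C(C)CCC[C@]1(C)C2=CCC[C@](C)(CC(=O)c3ccoc3)[C@H]2CC[C@H]1C`) gives > 100000 nM, which is a limit of the assay and not a number. Compound 2 (`C=C(C)CC[C@]1(C)C2=CCC[C@](C)(C[C@H](O)c3ccoc3)[C@H]2CC[C@H]1C`) gives 30200 nM in this assay. Compound 3 (`CC(C)=CCC[C@]1(C)C2=CCC[C@](C)(CC(=O)c3ccoc3)[C@H]2CC[C@H]1C`) has the same atoms as compound 1, joined differently: 2-methylprop-1-en-1-yl in place of 2-methylprop-2-en-1-yl on a saturated chain carbon, two bonds along the chain from a saturated ring carbon, with 2-methylprop-1-en-1-yl in place of 2-methylprop-2-en-1-yl on a saturated chain carbon, two bonds along the chain from a saturated ring carbon. No measured pair sizes this change, so no step beyond the scatter is expected in this assay. The expected step is an at least 1.1-fold lower number from compound 1 to compound 3 (0.04 log units; that floor lies within the scatter). For compound 3 the estimated value is 90000 nM, with an expected range of 30000 nM to 150000 nM.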

Compound 3, half-maximal inhibitory concentration: 54500 nM
Compound 3: the middle estimate sits 1.7-fold (0.22 log units) above what was measured; measured number inside the range.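

In this assay, 2-methylprop-1-en-1-yl in place of 2-methylprop-2-en-1-yl gives an at least 1.8-fold lower number from compound 1 to compound 3 (0.26 log units; that floor lies within the scatter), the first step readable at this position, so moving the double bond alone, with the same atoms, can register in this read-out. Compound 1 gives > 100000 nM, which is a limit of the assay and not a number. The step stays a floor because one end of it is that limit: the limit of > 100000 nM in this assay, at which 1 of the 3 values shown sits.

Open, as far as these compounds go, is whether the chain end tolerates other groups at this place, such as a saturated 4-methylpentyl chain or a terminal amine.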